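This account rests on a few compounds, and the source may have more. Where it says the series, first, only, none or still open, it means among the compounds named here.

Measured in a functional assay on HepG2 cells (Homo sapiens) for antiproliferative activity, read by MTT assay, with a stated time of 48 h; a higher number here means a weaker inhibitor, a lower number a stronger inhibitor:
Compound 1 `S=c1oc(-c2ccc3c(c2)OCCO3)nn1CN1CCN(C(c2ccccc2)c2ccccc2)CC1`: 9120 nM
Compound 2 `Cc1ccc(N2CCN(Cn3nc(-c4ccc5c(c4)OCCO5)oc3=S)CC2)c(C)c1`: 28400 nM
Compound 3 `S=c1oc(-c2ccc3c(c2)OCCO3)nn1CN1CCN(c2cccc(Cl)c2Cl)CC1`: > 50000 nM

Compound 3 has no exact number in this assay, only a limit of the assay, > 50000 nM. Compound 4 `S=c1oc(-c2ccc3c(c2)OCCO3)nn1CN1CCN(c2ccccc2)CC1` keeps the shared core but has phenyl in place of 2,3-dichlorophenyl on an amine nitrogen in a ring. Within the data shown here, only one measured step changes this same group: an at least 1.7-fold higher number from compound 2 to compound 3 (0.24 log units; that floor lies within the scatter). In that step, 2,3-dichlorophenyl replaces 2,4-dimethylphenyl, and its size is known only as a floor. Compound 2 gives 28400 nM and compound 1 gives 9120 nM, so among these two compounds the number differs with the group on that amine nitrogen. With so little evidence, only a moderate move toward a lower number is expected, and compound 4 could also end up reported only as a limit. The expected change is an at least 1.6-fold lower number from compound 3 to compound 4 (0.22 log units; that floor lies within the scatter). Compound 4 is estimated at about 30000 nM, with an expected range of 12000 nM to 50000 nM.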

Compound 4, half-maximal inhibitory concentration: > 50000 nM
Compound 4 gave a limit, no number (the forecaster's own chance of this, stated with the estimate: 35%); middle value at least 1.6-fold (0.22 log units) away from the limit.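

Compound 4, with plain phenyl on the amine nitrogen in the ring, gives only a limit of this assay, > 50000 nM. Taking away both chlorines therefore does not bring compound 4 to a measured number, but it and compound 3 cannot be ranked, and the step between them cannot be read, because both stop at the same limit: the limit of > 50000 nM in this assay, at which 2 of the 4 values shown sit. The one readable change is an at least 1.7-fold higher number from compound 2 to compound 4 (0.24 log units; that floor lies within the scatter), so phenyl and 2,4-dimethylphenyl are not shown to differ beyond the scatter.

On these data alone, it stays open how a single chlorine on the phenyl, or a benzyl group on that nitrogen, would read in this assay. As far as these compounds go, it is also open whether compound 1 reaches 9120 nM through having two phenyl rings on one carbon.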